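The compounds below may be only part of what the source reports. "The series", "measured", "known", "first", "only" and "open" are said of these compounds alone.

Compound 1, `CCOC(=O)c1sc2cccc(C)c2c1Nc1cc(OC)c(OC)c(OC)c1`, gives 4150 nM in a functional assay on MCF7 cells (Homo sapiens) for cytotoxicity, read by MTT assay, with a stated time of 72 h; a higher number here means a weaker inhibitor, a lower number a stronger inhibitor.
Compound 2, `COC(=O)c1sc2cc(OC)ccc2c1Nc1cc(OC)c(OC)c(OC)c1`, gives 0.7 nM in this assay.
Compound 3, `CCOC(=O)c1sc2c(OC)c(C)c(C)c(C)c2c1Nc1cc(OC)c(OC)c(OC)c1`, gives 95 nM in this assay.

Of the three compounds measured, compound 2 stands lowest in this assay, and its gaps to both others lie beyond the usual scatter: compound 3 is the nearest to it and compound 1 the furthest. Since every pair among these three differs in more than one place, no single structural change can be read off from them; the numbers show only that compound 2 is the strongest of the measured set.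

The unmeasured compound 4, `COC(=O)c1sc2cc(C)ccc2c1Nc1cc(OC)c(OC)c(OC)c1`, keeps everything of compound 2 except one group: methyl in place of methoxy on an aromatic carbon. Among the compounds with values here, no measured pair isolates this change. Compound 1 and compound 3, which carry methyl groups on the fused ring in place of or alongside methoxy, give far higher numbers than compound 2, yet they also differ from it elsewhere, so they give only a weak hint that removing the methoxy costs potency. On that basis a modest step toward a higher number, beyond the scatter but well short of the distance to compound 3, is expected from compound 2 to compound 4 in this assay, namely a 7.1-fold higher number from compound 2 to compound 4 (0.85 log units; beyond the scatter). Compound 4 is therefore estimated at 5 nM, within a range from 0.7 nM to 40 nM.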

Compound 4, half-maximal inhibitory concentration: 1.2 nM
Compound 4: middle estimate off by 4.2-fold (0.62 log units), on the high side, within the range that was stated.
By their numbers in this assay, from the lowest: compounds 2 and 4 (each within the scatter of the next); then compound 3; then compound 1.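

In this assay, within the data shown here, the exchange of methoxy for methyl gives a 1.7-fold higher number from compound 2 to compound 4 (0.23 log units; within the scatter), the first reading of a single change on the shared core. Among these compounds, at this position, on an aromatic carbon meta to a fused ring and para to a fused ring, a methoxy group and a methyl group therefore cannot be told apart in this assay, even though the exchange removes one heavy atom and the one hydrogen-bond acceptor counted for the group, something the earlier compounds, which all differ in more than one place, could not show. No supporting measurement is available to explain why this exchange leaves the number within the scatter.

Going by these compounds, the two groups compared here are both small and uncharged, so it remains open whether this position would accept an amine, a carboxylic acid or a longer chain such as butoxy with equal ease. On these data alone, it also remains open whether the same exchange would stay within the scatter at other positions on the fused ring system, or on a core that carries the ethyl ester instead of the methyl ester.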